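The compounds below may be only part of what the source reports. "The series", "measured", "known", "first", "only" and "open" are said of these compounds alone.

Three close relatives were tested in a functional assay on A498 cells (Homo sapiens) for cytotoxicity, read by sulforhodamine B assay, with a stated time of 48 h; on this read-out lower numbers stand for higher toxicity in this test and higher numbers for lower toxicity in this test. Compound 1 `ClCc1ccccc1Cn1cnc2c(Cl)ncnc21` gives 58900 nM in this assay, compound 2 `ClCc1ccc(Cn2cnc3nc(Cl)nc(Cl)c32)cc1` gives 49000 nM, and compound 3 `ClCc1ccccc1Cn1cnc2ncnc(Cl)c21` gives 57500 nM. Compound 2 sits no further from compound 1 or from compound 3 than the usual scatter of repeated measurements, so the three cannot be told apart on these numbers. Compound 4 `ClCc1ccc(Cn2cnc3ncnc(Cl)c32)cc1` has not yet been measured; compared with compound 2 it carries hydrogen in place of chloro on an aromatic carbon. Within the data shown here, no measured pair shows what this change does on its own, so the expected step is a 1.0-fold higher number from compound 2 to compound 4 (0.01 log units; within the scatter), nothing beyond the scatter in either direction. Compound 4 is therefore expected to give about 50000 nM, with a likely range from 20000 nM to 120000 nM.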

Compound 4, concentration lethal to 50% of the cells: 6300 nM
The estimate for compound 4 lay 7.9-fold (0.90 log units) above the measured number; the whole stated range lies above it.
By their numbers in this assay, from the lowest: compound 4; then compounds 2, 3 and 1 (each within the scatter of the next).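

Swapping the chloro group between the two ring nitrogen atoms for hydrogen gives a 7.8-fold lower number from compound 2 to compound 4 (0.89 log units; beyond the scatter) in this assay, so the lower number points to higher toxicity in this test. The earlier compounds shown here could not be told apart, whereas this pair shows that the read-out responds to what sits at this one position. Nothing available explains this step. The pair leaves open whether an amine or a methoxy group at this position would give a number nearer that of compound 2 or compound 4.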